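The source may report more compounds than this note shows. Statements on the series, on what has been measured and on what is new or still open speak of the compounds shown alone.

Among the compounds with values here, in a functional assay on A-375 cells (Homo sapiens) for inhibition, read by MTT assay, with a stated time of 5 days (on this read-out lower numbers stand for stronger inhibition and higher numbers for weaker inhibition), two compounds have numbers so far. Compound 2 (`CC(=O)Nc1nccc(-c2sc(C3CCN(C4CC4)CC3)nc2-c2cccc(NS(=O)(=O)c3cc(F)ccc3F)c2F)n1`) gives 1.48 nM and is the lower of the two, by a gap well beyond the scatter of repeat measurements. Compound 1 (`NCCCc1nc(-c2cccc(NS(=O)(=O)c3cc(F)ccc3F)c2F)c(-c2ccnc(N)n2)s1`) gives 39.5 nM and so inhibits more weakly.

Compound 3 (`CC(=O)Nc1nccc(-c2sc(CCCN)nc2-c2cccc(NS(=O)(=O)c3cc(F)ccc3F)c2F)n1`) has not yet been measured. It keeps the rest of compound 2 and changes one group: 3-aminopropyl in place of 1-cyclopropylpiperidin-4-yl on an aromatic carbon, next to the ring nitrogen and next to the ring sulfur (3-aminopropyl in place of 1-cyclopropylpiperidin-4-yl on an aromatic carbon).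

Within the data shown here, no two measured compounds differ in one place alone, so no measured step gives the size of this change directly. Among the measured compounds shown here, the only clue is that compound 1, which also carries 3-aminopropyl, sits at 39.5 nM on the weaker side. Compound 1 also differs from compound 3 elsewhere, so its number is only a rough guide.

A weaker result is expected, with an estimated change a 6.8-fold higher number from compound 2 to compound 3 (0.83 log units; beyond the scatter) toward a higher number and beyond the scatter. For compound 3 the expected value is 10 nM with 2.5 nM to 40 nM as the likely range.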

Compound 3, half-maximal inhibitory concentration: 208 nM
The estimate for compound 3 lay 21-fold (1.32 log units) below the measured number; measured number above the stated range.
By their numbers in this assay, from the lowest: compound 2; then compound 1; then compound 3.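

In this assay, putting 3-aminopropyl in place of 1-cyclopropylpiperidin-4-yl on the aromatic carbon next to the ring nitrogen and next to the ring sulfur gives a 140-fold higher number from compound 2 to compound 3 (2.15 log units; beyond the scatter), so the group held at this position has a large bearing on the read-out. With 3-aminopropyl kept at that position, acetyl in place of hydrogen on a nitrogen on an aromatic ring gives a 5.3-fold higher number from compound 1 to compound 3 (0.72 log units; beyond the scatter), a modest step in the weaker direction, which shows that the acetyl does not by itself account for the low number of compound 2. Nothing available here explains the size of either step.

The compounds shown cannot tell whether the large step belongs to the six-membered ring or to the cyclopropyl on its nitrogen, a question that a plain piperidin-4-yl, with only a hydrogen on that nitrogen, or a 1-methylpiperidin-4-yl would address. From the compounds shown here alone, it also remains open whether the acetyl step keeps its direction and size when 1-cyclopropylpiperidin-4-yl occupies the position, which would take the partner of compound 2 with a free amine in place of the acetylated one.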